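Methyl in place of hydrogen on the core of compound 1

The compounds below may be only part of what the source reports. "The series", "measured", "known", "first", "only" and "open" are said of these compounds alone.

The account follows a single change made to compound 1, whose structure is `Cc1ccccc1C(=O)NC(CCN(C)C)c1ccc(Cl)cc1`. In an assay on NIH3T3 cells with Urotensin-2 receptor (Homo sapiens) as the target (on this read-out lower numbers stand for smaller maximal responses and higher numbers for larger maximal responses), compound 1 gives 175%. Among the three numbers available, this places compound 1 second highest. Its nearest neighbour is compound 3, built as `COc1cccc(C(=O)NC(CCN(C)C)c2ccc(Cl)cc2)c1C`, which in this assay gives 179%, a value that lies within the usual scatter of that of compound 1. Furthest away stands compound 2, `CN(C)CC[C@H](NC(=O)c1ccc2ccccc2c1)c1ccc(Cl)cc1`, which in this assay gives 109%, a number well below that of compound 1 and beyond the scatter.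

Compound 4, with the structure `Cc1ccc(C)c(C(=O)NC(CCN(C)C)c2ccc(Cl)cc2)c1`, has not yet been measured. It differs from compound 1 in one place: methyl in place of hydrogen on an aromatic carbon.

For the measured compounds named here, only one measured step bears on this change, the one from compound 1 to compound 3, where a methoxy group entered on an aromatic carbon and the result was a number 4 percentage points higher from compound 1 to compound 3 (within the scatter). That step did not leave the scatter. On this basis the estimate for compound 4 is a step of no change at the digits printed from compound 1 to compound 4 (within the scatter), that is, none beyond the scatter in either direction.

The value expected for compound 4 in this assay is therefore 175%, with a range from 150% to 200%.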

Compound 4, largest response reached (reported as efficacy), in percent of the reference or control that the assay uses: 164%
Compound 4: middle estimate off by 11 percentage points, on the high side; low and high end bracket the measured number.
By their numbers in this assay, from the lowest: compound 2; then compound 4; then compounds 1 and 3 (each within the scatter of the next).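

On the ring of compound 1, the change from 2-methylphenyl to 2,5-dimethylphenyl, which puts a methyl group meta to a large group and para to the existing methyl group, produced a number 11 percentage points lower from compound 1 to compound 4 (beyond the scatter) in this assay. This is the first single substitution on this ring shown to move the read-out beyond the scatter, since the methoxy change gave only a number 4 percentage points higher from compound 1 to compound 3 (within the scatter) and so left no measurable shift. The loss is small for a single added carbon, and compound 4 at 164% still gives a much larger maximal response than the control level of the assay would suggest, although no measurement presented here accounts for the drop.

What the compounds shown leave open is whether this position would respond in the same direction to a fluorine atom, a hydroxyl group, an amine, a carboxylic acid or a longer chain such as ethyl. They also leave open whether the methyl step would be repeated on a ring without the existing methyl group, as a single pair of compounds sets no trend.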